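Compound 3 and a 4-nitrophenyl replacement

The source may hold more compounds than are shown below. What is called first, only, known or untested is meant among the compounds shown, and "the series" means these compounds.

Measured in a functional assay on MCF7 cells (Homo sapiens) for cytotoxicity, read by MTT assay, with a stated time of 96 h; a lower number here means a stronger inhibitor, a higher number a weaker inhibitor:
compound 1 `COc1cc(C(=O)c2cn(-c3cccc(C)c3)cc2-c2ccccc2F)cc(OC)c1OC`: 190 nM
compound 2 `COc1cc(C(=O)c2cn(-c3cccc(N)c3)cc2-c2ccccc2F)cc(OC)c1OC`: 17 nM
compound 3 `COc1cc(C(=O)c2cn(-c3ccc(C)cc3)cc2-c2ccccc2F)cc(OC)c1OC`: 44 nM

Compound 3, at 44 nM, has the second highest number of the three. It lies between its two companions, and both gaps are beyond the scatter: a 2.6-fold higher number from compound 2 to compound 3 (0.41 log units; beyond the scatter), and a 4.3-fold lower number from compound 1 to compound 3 (0.64 log units; beyond the scatter).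

Compound 4 `COc1cc(C(=O)c2cn(-c3ccc(C)cc3)cc2-c2ccc([N+](=O)[O-])cc2)cc(OC)c1OC` keeps the 4-methylphenyl group of compound 3 but changes a different site, with 4-nitrophenyl in place of 2-fluorophenyl on an aromatic carbon. Among the compounds with values here, no measured step bears directly on this change, since all three measured compounds carry the 2-fluorophenyl group. Within the data shown here, the only guide is indirect. Single changes on the group at the aromatic nitrogen gave an 11-fold lower number from compound 1 to compound 2 (1.05 log units; beyond the scatter), a large step, and the modest step already noted from compound 1 to compound 3. One change can therefore matter in this assay, but these steps do not show what happens at the new site.

A modest step towards a higher number is expected, and its direction is a tentative judgement. The estimate means a 2.3-fold higher number from compound 3 to compound 4 (0.36 log units; beyond the scatter), an expected shift with wide uncertainty. For compound 4 the estimated value is 100 nM, with an expected range from 20 nM to 500 nM.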

Compound 4, half-maximal inhibitory concentration: 200 nM
Compound 4: middle estimate off by 2.0-fold (0.30 log units), on the low side; the range from low to high includes it.
By their numbers in this assay, from the lowest: compound 2; then compound 3; then compounds 1 and 4 (each within the scatter of the next).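

The aromatic carbon next to the ring atom that bears a large group now proves responsive in this assay: with the 4-methylphenyl group held fixed, 4-nitrophenyl in place of 2-fluorophenyl gives a 4.5-fold higher number from compound 3 to compound 4 (0.66 log units; beyond the scatter). Within the data shown here, the earlier steps all concerned the group on the ring nitrogen, such as a 4.3-fold lower number from compound 1 to compound 3 (0.64 log units; beyond the scatter), so this is the first sign that the aryl group on this carbon also affects the number, by a step likewise classed as modest. Nothing measured here accounts for the change.

This single swap alters both the substituent and where it sits on the phenyl ring, so the effects of the two remain inseparable; a 4-fluorophenyl or a 2-nitrophenyl group on this carbon would divide them. As far as these compounds go, it also remains open how a 4-aminophenyl group would behave at this site, and whether the 4-nitrophenyl group would shift the number similarly alongside the 3-aminophenyl group of compound 2.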